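A few compounds are considered here, and "the series" means these few. Any claim that something is new, unique, unknown or untested is made for them only; others in the source may bear on it.

Measured compounds in a functional assay on the whole organism (strain NMRI) with Mus musculus as the target, with a stated time of 0.5 h; on this read-out lower numbers stand for an effect already at smaller amounts and higher numbers for an effect only at larger amounts of compound:
- compound 1 `C#CCO/N=C/c1c(-c2ccc(C)cc2)nc2c(C)cccn12`, where compound 1 gives 20 mg/kg
- compound 2 `C#CCO/N=C/c1c(-c2ccc(F)cc2)nc2ccc(Br)cn12`, where compound 2 gives 40 mg/kg
- compound 3 `Cc1ccc(-c2nc3c(C)cccn3c2/C=N/O)cc1`, where compound 3 gives 20 mg/kg

Compound 3 differs from compound 1 only by hydrogen in place of propargyl on an oxygen, and that step, no change at the digits printed from compound 1 to compound 3 (within the scatter), stays within the scatter. Compound 2 stands apart from compound 1 in its core; the difference between the two cores is not broken down here. Compound 4 `O/N=C/c1c(-c2ccc(F)cc2)nc2ccc(Br)cn12`, not yet measured in this assay, differs from compound 2 by hydrogen in place of propargyl on an oxygen, the same change that leads from compound 1 to compound 3, made at the same kind of place; the change occurs twice among the compounds shown. Because no change at the digits printed from compound 1 to compound 3 (within the scatter) showed no shift, the step from compound 2 to compound 4 is expected to be no change at the digits printed from compound 2 to compound 4 (within the scatter) in this assay. Compound 4 is therefore estimated at 40 mg/kg, between 20 mg/kg and 80 mg/kg.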

Compound 4, minimum effective dose: 40 mg/kg
The estimate for compound 4 equals the measured number at the digits printed, within the range that was stated.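

In this assay, the new step, with hydrogen in place of propargyl on an oxygen, reads no change at the digits printed from compound 2 to compound 4 (within the scatter), and it can be set beside the same change on the core of compound 1: the same change on two cores in this assay, no change at the digits printed (within the scatter) from compound 1 to compound 3 and no change at the digits printed (within the scatter) from compound 2 to compound 4, 1.0-fold (0.00 log units) apart, within the scatter of two such steps

On these two cores, then, the change carries over without a shift in this assay. This rests on two pairs only and shows nothing about a third core, nor does it explain why the propargyl group can leave without a shift.

The compounds shown carry only propargyl or hydrogen on that oxygen. From the compounds shown here alone, it remains open whether a methyl group, a longer chain or a chain ending in an amine would fit the same picture.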